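Replacing 4-Methoxyphenoxy with Cyclohexylmethyl in Compound 1

This account rests on a few compounds, and the source may have more. Where it says the series, first, only, none or still open, it means among the compounds named here.

Measured so far in an assay on HEK293 cells for displacement of a labelled ligand from Melanocortin receptor 4 (Homo sapiens); on this read-out higher numbers stand for weaker inhibition and lower numbers for stronger inhibition:
compound 1 `COc1ccc(OCC(=O)N2CCN(c3ccc(C(F)(F)F)cc3[C@@H](N)CC(C)C)CC2)cc1`: 3800 nM
compound 2 `CC(C)C[C@H](N)c1cc(C(F)(F)F)ccc1N1CCN(C(=O)CC(C)C(=O)c2ccc(Cl)cc2)CC1`: 1100 nM
compound 3 `CC(C)C[C@H](N)c1cc(C(F)(F)F)ccc1N1CCN(C(=O)COc2ccc(Cl)cc2)CC1`: 2900 nM

Compound 1 stands highest of these three numbers, though the gap to compound 3 is small: a 1.3-fold lower number from compound 1 to compound 3 (0.12 log units; within the scatter), whereas a 3.5-fold lower number from compound 1 to compound 2 (0.54 log units; beyond the scatter).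

Compound 4 `CC(C)C[C@H](N)c1cc(C(F)(F)F)ccc1N1CCN(C(=O)CCC2CCCCC2)CC1` is compound 1 with one change: cyclohexylmethyl in place of 4-methoxyphenoxy on a saturated chain carbon bound to a carbonyl carbon. For the measured compounds named here, two measured steps touch the same place. a 3.5-fold lower number from compound 1 to compound 2 (0.54 log units; beyond the scatter) and a 2.6-fold higher number from compound 2 to compound 3 (0.42 log units; beyond the scatter); in both, the group joined through carbon rather than through oxygen went with the lower number. On that basis a modest lowering is expected for compound 4, a 2.1-fold lower number from compound 1 to compound 4 (0.32 log units; beyond the scatter). Compound 4 is therefore estimated at 1800 nM, within a range of 600 nM to 5500 nM.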

Compound 4, inhibition constant: 5700 nM
Compound 4: middle estimate off by 3.2-fold (0.50 log units), on the low side; measured number outside the range, above it.
By their numbers in this assay, from the lowest: compound 2; then compounds 3, 1 and 4 (each within the scatter of the next).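

In this assay a carbon link does not by itself go with a lower number: the steps are a 1.5-fold higher number from compound 1 to compound 4 (0.18 log units; within the scatter) and a 2.0-fold higher number from compound 3 to compound 4 (0.29 log units; within the scatter), both within the scatter, so compound 4 goes against the pattern suggested by compounds 1, 2 and 3. Compound 2 alone stands apart, with a 5.2-fold higher number from compound 2 to compound 4 (0.71 log units; beyond the scatter), so the lower number here goes with 1-((4-chlorophenyl)carbonyl)ethyl and not with a carbon link as such. Nothing measured here explains these differences.

Still open, as far as these compounds go, is whether a plain phenyl ring on the same carbon-linked chain, or an amine or carboxylic acid at this place, would lower the number.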